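The source may hold more compounds than are shown below. What is called first, only, known or untested is meant among the compounds shown, and "the series" means these compounds.

Compound 3 `CCC(C(=O)N1CCN(c2ccccc2Cl)CC1)N1C(=O)CCC1=O` gives 25% in a functional assay on the whole organism (strain Swiss) with Mus musculus as the target, in the maximal electroshock model, with a stated time of 0.5 h, at a dose of 300 mg/kg by the intraperitoneal route (a higher number here means a stronger effect of the compound at the dose given, a lower number a weaker effect), the lowest of the three numbers measured. Compound 1 `COc1cccc(N2CCN(C(=O)C(C)N3C(=O)CCC3=O)CC2)c1` gives 50%, and compound 2 `CC(C(=O)N1CCN(c2ccc(Cl)cc2)CC1)N1C(=O)CCC1=O` gives 100%. Compound 4 `CCC(C(=O)N1CCN(c2cccc(OC)c2)CC1)N1C(=O)CCC1=O` differs from compound 3 in one place: 3-methoxyphenyl in place of 2-chlorophenyl on an amine nitrogen in a ring. Among the compounds with values here, the only measured step that touches the group on the ring nitrogen is a number 50 percentage points higher from compound 1 to compound 2 (beyond the scatter), yet that step exchanges 3-methoxyphenyl for 4-chlorophenyl, not 2-chlorophenyl, so it bears on the present change only loosely. Compound 1, which also carries 3-methoxyphenyl, shows a higher number than compound 3. A moderate rise is therefore expected, and compound 4 is estimated at 45%, within 15% to 80%. The expected step is a number 20 percentage points higher from compound 3 to compound 4 (beyond the scatter).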

Compound 4, a percentage reported as activity, at one dose (the size of the read-out at that dose, not a potency): 0%
Compound 4: the middle estimate sits 45 percentage points above what was measured; measured number below the stated range.
By their numbers in this assay, from the lowest: compound 4; then compound 3; then compound 1; then compound 2.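

Exchanging 2-chlorophenyl for 3-methoxyphenyl on the amine nitrogen in the ring lowers the reading in this assay (a number 25 percentage points lower from compound 3 to compound 4 (beyond the scatter)), the first measured step from 2-chlorophenyl. Within the data shown here, the compounds also give the first step on the saturated chain carbon: with 3-methoxyphenyl held constant, methyl in place of hydrogen gives a drop (a number 50 percentage points lower from compound 1 to compound 4 (beyond the scatter)). No supporting data account for either fall. Going by these compounds, it remains open whether the same methyl would lower the reading with 4-chlorophenyl on the ring nitrogen, and how a propyl chain at that carbon or a 3-chlorophenyl group on that nitrogen would read.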